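Thioether-linked analogues of a sulfonamide TRPV1 antagonist

The compounds below may be only part of what the source reports. "The series", "measured", "known", "first", "only" and "open" are said of these compounds alone.

Compound 1 `CC(C(=O)NCc1ccc(C(C)(C)C)nc1N1CCCC1)c1ccc(NS(C)(=O)=O)c(F)c1`: 1.2 nM
Compound 2 `CC(C(=O)NCc1ccc(C(C)(C)C)nc1SCCCN1CCCC1)c1ccc(NS(C)(=O)=O)c(F)c1`: 17.1 nM

In an assay on cells for antagonist activity at transient receptor potential cation channel subfamily V member 1 (Homo sapiens), read by FLIPR and calcium flux, with a stated time of 6 min (a higher number here means a weaker inhibitor, a lower number a stronger inhibitor), compound 2 gives 17.1 nM, the higher of the two numbers recorded; compound 1, its nearest neighbour, shows a 14-fold higher number from compound 1 to compound 2 (1.15 log units; beyond the scatter). Compound 3 `COc1ccc(CSc2nc(C(C)(C)C)ccc2CNC(=O)C(C)c2ccc(NS(C)(=O)=O)c(F)c2)cc1` differs from compound 2 by 4-methoxyphenyl in place of 2-(pyrrolidin-1-yl)ethyl on a saturated chain carbon bound to a sulfur. Among the measured compounds shown here, no measured step bears on this exchange; the only recorded step concerns the link to the aromatic carbon, which is kept here. Compound 3 is therefore expected to give 15 nM, within 4 nM to 60 nM, which means an estimated 1.1-fold lower number from compound 2 to compound 3 (0.06 log units; within the scatter), not beyond the scatter.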

Compound 3, inhibition constant: 3.5 nM
Compound 3: middle estimate off by 4.3-fold (0.63 log units), on the high side; the measured number lies below the stated range.
By their numbers in this assay, from the lowest: compound 1; then compound 3; then compound 2.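

In this assay, the sulfur-linked position does not depend on the pyrrolidine-bearing chain: 4-methoxyphenyl in place of 2-(pyrrolidin-1-yl)ethyl gives a 4.9-fold lower number from compound 2 to compound 3 (0.69 log units; beyond the scatter). Yet (4-methoxybenzyl)sulfanyl in place of pyrrolidin-1-yl on the aromatic carbon still gives a 2.9-fold higher number from compound 1 to compound 3 (0.46 log units; beyond the scatter), so the gap between the thioether and compound 1 narrows without closing. Nothing at hand accounts for either difference. The compounds shown leave open whether the methoxy group matters, as an unsubstituted benzyl on the sulfur would show. They also leave open how a carboxylic acid at the end of the chain would compare.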